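The source may hold more compounds than are shown below. What is called first, only, known or untested is meant among the compounds shown, and "the series" means these compounds.

Measured in a functional assay on MGC-803 cells (Homo sapiens) for inhibition, read by CCK-8 assay, with a stated time of 48 h; a higher number here means a weaker inhibitor, a lower number a stronger inhibitor:

- Compound 1 `COc1ccc(CN(C(=O)CSc2nc3ccccc3o2)c2cc(OC)c(OC)c(OC)c2)cc1` gives 450 nM
- Compound 2 `COc1ccc(CN(C(=O)CSC(=S)N2CCN(C(C)=O)CC2)c2cc(OC)c(OC)c(OC)c2)cc1` gives 480 nM
- Compound 3 `COc1ccc(CN(C(=O)CSC(=S)N2CCCc3cc(C)ccc32)c2cc(OC)c(OC)c(OC)c2)cc1` gives 6490 nM

Compound 3 has the highest number of the three and is the weakest inhibitor, with its gaps to both other compounds beyond the scatter. Compound 4 `COc1ccc(CN(C(=O)CSC(=S)N2CCc3ccccc3C2)c2cc(OC)c(OC)c(OC)c2)cc1` keeps the shared core but swaps one group on the thiocarbonyl carbon: 1,2,3,4-tetrahydroisoquinolin-2-yl in place of 6-methyl-1,2,3,4-tetrahydroquinolin-1-yl on a thiocarbonyl carbon.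

The most relevant evidence comes from the same place, where a 14-fold higher number from compound 2 to compound 3 (1.13 log units; beyond the scatter). The other step, a 1.1-fold higher number from compound 1 to compound 2 (0.03 log units; within the scatter), shows two very different groups on a sulfur giving similar numbers. Only compound 3 stands apart, at 6490 nM, so removing its 6-methyl-1,2,3,4-tetrahydroquinolin-1-yl group may recover part of that loss. Recovery is expected to be partial, since the entering group also has a six-membered aromatic ring of carbon only. The expected change is a 4.1-fold lower number from compound 3 to compound 4 (0.61 log units; beyond the scatter). For compound 4 the estimated value is 1600 nM, with an expected range from 400 nM to 6500 nM.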

Compound 4, half-maximal inhibitory concentration: 5940 nM
Beside the measured number, compound 4's estimate is 3.7-fold (0.57 log units) below it; low and high end bracket the measured number.
By their numbers in this assay, from the lowest: compounds 1 and 2 (each within the scatter of the next); then compounds 4 and 3 (each within the scatter of the next).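

In this assay, 1,2,3,4-tetrahydroisoquinolin-2-yl in place of 6-methyl-1,2,3,4-tetrahydroquinolin-1-yl on the thiocarbonyl carbon leaves the result essentially unchanged (a 1.1-fold lower number from compound 3 to compound 4 (0.04 log units; within the scatter)), so the loss seen with compound 3 is not tied to that one group. It is shared by a second group with a six-membered aromatic ring of carbon only, and the gaps to the stronger compounds remain (a 12-fold higher number from compound 2 to compound 4 (1.09 log units; beyond the scatter); a 13-fold higher number from compound 1 to compound 4 (1.12 log units; beyond the scatter)), although compound 1 goes against any simple link to such a ring, since its group on sulfur holds one too. No measurement shown explains the loss.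

Still open, from the compounds shown here alone, is whether the aromatic ring or the acetyl group of compound 2 decides the result. Piperidin-1-yl and 4-methylpiperazin-1-yl on the thiocarbonyl carbon would help separate the two.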